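This account rests on a few compounds, and the source may have more. Where it says the series, first, only, none or still open, it means among the compounds named here.

Measured compounds:
compound 1 `O=C(/C=C\Nc1ccc(F)cc1)c1nc(-c2ccc(F)cc2)n2ccccc12` — in a functional assay on MDA-MB-231 cells (Homo sapiens) for cytotoxicity, read by MTT assay, with a stated time of 48 h (a lower number here means a stronger inhibitor, a higher number a weaker inhibitor), compound 1 gives 25100 nM.
compound 2 `COc1ccc(N/C=C\C(=O)c2nc(-c3ccc(C(F)(F)F)cc3)n3ccccc23)cc1OC` — in this assay compound 2 gives > 30000 nM, a limit of the assay and not a number.

Among the measured compounds shown here, compound 1 is the only compound of the pair with a numerical value in this assay; the other value shown is a limit. One of the two values sits at the limit of > 30000 nM in this assay, at which 1 of the 2 values shown sits, and that one belongs to compound 2. For the measured compounds named here, no step between two measured compounds can be computed here, so the pair gives no measured direction for any structural change.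

Compound 3 `COc1ccc(N/C=C\C(=O)c2nc(-c3ccc(F)cc3)n3ccccc23)cc1` is not yet measured. Compound 3 differs from compound 1 by methoxy in place of fluoro on an aromatic carbon. Nothing measured in this series isolates that change; compound 2 carries methoxy groups on the same ring but also differs elsewhere, so its limit cannot be read as the effect of the methoxy alone.

The step from compound 1 to compound 3 is expected to stay within the scatter, a 1.1-fold higher number from compound 1 to compound 3 (0.05 log units; within the scatter), with a real chance that compound 3 returns only a limit. Compound 3 is therefore estimated at 28000 nM, expected between 12000 nM and 70000 nM.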

Compound 3, half-maximal inhibitory concentration: > 30000 nM
Compound 3 ended at the assay's limit (the forecaster's own chance of this, stated with the estimate: 45%); middle value at least 1.0-fold (0.02 log units) away from the limit.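

Among the compounds shown here, the change from (4-fluorophenyl)amino to (4-methoxyphenyl)amino gives the first single-place step that can be read: in this assay, methoxy in place of fluoro on this aromatic carbon gives an at least 1.1-fold higher number from compound 1 to compound 3 (0.07 log units; that floor lies within the scatter). This step is only a floor, so it shows no lower number with methoxy at this position, but it cannot separate a real loss from no change. Any further step that ends at the limit would be just as unsized: the limit of > 30000 nM in this assay, at which 2 of the 3 values shown sit.

The steps involving compound 2 cannot be read, so the effect of the groups it carries stays unresolved. On these data alone, it also stays open whether a different group at this position, such as an amine, a carboxylic acid or a longer chain, would give a number clearly lower than that of compound 1, and whether the 4-fluorophenyl group shared by compound 1 and compound 3 has any part in these values.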